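The compounds below may be only part of what the source reports. "The series", "measured", "known", "first", "only" and "open" are said of these compounds alone.

Working notes on the series, all read in a functional assay on HepG2 cells (Homo sapiens) for cytotoxicity, read by MTT assay, with a stated time of 24 h; a lower number here means a stronger inhibitor, a higher number a weaker inhibitor. Compound 2 (`CN1C/C(=C\c2ccncc2)C(=O)/C(=C/c2ccccc2F)C1`) gives 4600 nM and compound 3 (`CN1C/C(=C\c2ccncc2)C(=O)/C(=C/c2cc([N+](=O)[O-])ccc2F)C1`) gives 5200 nM, so these two stand level. Compound 1 (`CN1C/C(=C\c2cccnc2)C(=O)/C(=C/c2ccc(F)cc2Br)C1`) gives 13000 nM, a higher number than compound 2 by more than the scatter.

The step followed here leads to compound 4 (`CN1C/C(=C\c2ccncc2)C(=O)/C(=C/c2ccc(F)cc2Br)C1`): 2-bromo-4-fluorophenyl in place of 2-fluorophenyl on a double-bonded chain carbon bound to a double-bonded ring carbon. The 2-bromo-4-fluorophenyl group enters in place of 2-fluorophenyl on a double-bonded chain carbon bound to a double-bonded ring carbon.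

One measured step changes this same phenyl group: a 1.1-fold higher number from compound 2 to compound 3 (0.05 log units; within the scatter), with nitro in place of hydrogen on an aromatic carbon. Compound 1, at 13000 nM, carries the 2-bromo-4-fluorophenyl group too, but it differs from compound 4 elsewhere, so it is only a loose guide. A small upward move is therefore expected, perhaps none beyond the scatter.

The expected move is a 1.5-fold higher number from compound 2 to compound 4 (0.18 log units; within the scatter). The estimate for compound 4 is 7000 nM, with an expected range of 3200 nM to 15000 nM.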

Compound 4, half-maximal inhibitory concentration: 9200 nM
Beside the measured number, compound 4's estimate is 1.3-fold (0.12 log units) below it; the range from low to high includes it.
By their numbers in this assay, from the lowest: compounds 2, 3, 4 and 1 (each within the scatter of the next, the first and the last beyond it).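

In this assay, 2-bromo-4-fluorophenyl in place of 2-fluorophenyl on a double-bonded chain carbon bound to a double-bonded ring carbon gives a 2.0-fold higher number from compound 2 to compound 4 (0.30 log units; within the scatter), so this position accepts the group without a step beyond the scatter, though at the edge of it. For the compounds shown here, the pyridine can now be read on its own for the first time, with the 2-bromo-4-fluorophenyl group held fixed: pyridin-4-yl in place of pyridin-3-yl gives a 1.4-fold lower number from compound 1 to compound 4 (0.15 log units; within the scatter), and these two compounds stand level. No measurement at hand gives a cause for either step.

Open, going by these compounds, is whether a carboxylic acid or an amine on the phenyl group at this place would move the number beyond the scatter. Also open, on these data alone, is how pyridin-2-yl would read against pyridin-3-yl and pyridin-4-yl on the same core.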